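Flipping the Double Bond Geometry of Compound 2

The source may hold more compounds than are shown below. What is called first, only, known or untested is meant among the compounds shown, and "the series" means these compounds.

Compound 2 `COc1ccc(Cc2ccc3c(c2)/C(=C\c2cccc(OCc4cn(Cc5ccccc5)nn4)c2)C(=O)N3)cc1` shares its core with compound 1 `CC(=O)c1ccc2c(c1)/C(=C/c1cccc(OCc3cn(Cc4ccccc4)nn3)c1)C(=O)N2`. In a functional assay on A549 cells (Homo sapiens) for inhibition, read by MTT assay, with a stated time of 48 h (on this read-out higher numbers stand for weaker inhibition and lower numbers for stronger inhibition), compound 1 gives 36300 nM. In this assay compound 2 reaches only > 50000 nM, which is a limit of the assay and not a measured number. Compound 2 thus stands at the limit of > 50000 nM in this assay, at which 1 of the 2 values shown sits, the weaker end of the two values shown. Compound 3 `COc1ccc(Cc2ccc3c(c2)/C(=C/c2cccc(OCc4cn(Cc5ccccc5)nn4)c2)C(=O)N3)cc1` differs from compound 2 in one respect: the two compounds have the same atoms and bonds and differ only in configuration as drawn: 1 of 1 stereo elements differ; a double bond is drawn E in compound 2 and Z in compound 3. Going by the values given here, no step between two measured compounds isolates this change, so its size in this assay cannot be read from the data; compound 1 shares the drawn configuration of compound 3 but also carries a different group, so its value alone settles nothing. The expected step is an at least 1.1-fold lower number from compound 2 to compound 3 (0.04 log units; that floor lies within the scatter), not beyond the scatter. Compound 3 is estimated at 45000 nM, within a range from 18000 nM to 110000 nM.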

Compound 3, half-maximal inhibitory concentration: 30500 nM
Estimate against measurement, compound 3: 1.5-fold (0.17 log units) above; low and high end bracket the measured number.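

Going by these compounds alone, compounds 2 and 3 now give a first reading of the double bond geometry in this assay: an at least 1.6-fold lower number from compound 2 to compound 3 (0.21 log units; that floor lies within the scatter). From the compounds shown here alone, the value of compound 2 is a limit of the assay and not a number, so this step gives only a floor and the true size of the change stays unknown: the limit of > 50000 nM in this assay, at which 1 of the 3 values shown sits. At the aromatic carbon, with the drawn configuration kept, the exchange of acetyl for 4-methoxybenzyl gives a 1.2-fold lower number from compound 1 to compound 3 (0.08 log units; within the scatter), so the two groups cannot be told apart on this read-out.

Going by these compounds, whether the geometry of the double bond matters at all in this assay remains open, since the floor of its step does not clear the scatter. On these data alone, how an amine or a carboxylic acid would read on that aromatic carbon also remains open.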